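Removing trifluoromethyl: what compound 3 may show

The source may hold more compounds than are shown below. What is called first, only, known or untested is meant among the compounds shown, and "the series" means these compounds.

Measured so far in a functional assay on HL-60 cells (Homo sapiens) for cytotoxicity, read by luminescence and CellTiter-Glo, with a stated time of 3 days (on this read-out lower numbers stand for stronger inhibition and higher numbers for weaker inhibition), as follows
compound 1 `N#Cc1ccc(NC(=O)c2cccc(Br)c2O)cc1` gives 2910 nM
compound 2 `N#Cc1ccc(NC(=O)c2cc(C(F)(F)F)ccc2O)cc1` gives 3120 nM

In this assay compound 2 stands at 3120 nM and lies within the scatter of compound 1 at 2910 nM, so these two numbers cannot be told apart. Compound 3 `N#Cc1ccc(NC(=O)c2ccccc2O)cc1` has not yet been measured. It follows from compound 2 by hydrogen in place of trifluoromethyl on an aromatic carbon, with hydrogen in place of trifluoromethyl on an aromatic carbon. Going by the values given here, no measured pair shows this change alone, so the data give no direct guide to its size. Among the compounds with values here, the only hint is that compound 1 at 2910 nM carries bromine and compound 2 at 3120 nM carries trifluoromethyl, while compound 3 has neither. A moderate move toward a higher number, meaning weaker inhibition, is therefore expected, and the estimated change is a 2.2-fold higher number from compound 2 to compound 3 (0.35 log units; beyond the scatter) in this assay for this replacement. This is a tentative expectation resting on very little data. Compound 3 is estimated at 7000 nM, with an expected range of 2500 nM to 20000 nM overall.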

Compound 3, half-maximal inhibitory concentration: 4620 nM
For compound 3 the middle estimate is 1.5-fold (0.18 log units) above the measured one; low and high end bracket the measured number.
By their numbers in this assay, from the lowest: compounds 1, 2 and 3 (each within the scatter of the next).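

In this assay, going by these compounds alone, the replacement of trifluoromethyl by hydrogen on the aromatic carbon para to a hydroxy group gives the first direct reading at this position, a 1.5-fold higher number from compound 2 to compound 3 (0.17 log units; within the scatter), so at this position the two groups cannot be told apart on this read-out. The replacement of bromo by hydrogen on an aromatic carbon, a 1.6-fold higher number from compound 1 to compound 3 (0.20 log units; within the scatter), reads the same way, which means that for these three compounds neither substituent can be separated from plain hydrogen, and the unsubstituted compound 3 cannot be ranked against either of the others. No measured evidence is available that would explain either step.

The compounds shown leave open whether any group on this aromatic carbon can move the number beyond the scatter at all, since a substituent of a different kind, such as an amine, a carboxylic acid or a longer alkyl chain, has no value here to set against hydrogen. They also leave open whether the nitrile or the hydroxy group matters to the activity, as both are present in all three compounds.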